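The source may report more compounds than this note shows. Statements on the series, on what has been measured and on what is new or still open speak of the compounds shown alone.

Measured in a functional assay on HeLa cells (Homo sapiens) for inhibition, read by CCK-8 assay, with a stated time of 48 h; a lower number here means a stronger inhibitor, a higher number a weaker inhibitor:
- Compound 1 `CC(C)c1ccc(Oc2ccc(O)c(O)c2)c(-c2ccsc2S(=O)(=O)NCCNC(=S)Nc2cc(C(F)(F)F)cc(C(F)(F)F)c2)c1`: > 20000 nM (a limit)
- Compound 2 `O=S(=O)(NCCNC(=S)Nc1cc(C(F)(F)F)cc(C(F)(F)F)c1)c1sccc1-c1ccccc1Oc1ccc(O)c(O)c1`: > 50000 nM (a limit)

Compound 2 has no numerical value in this assay, only the limit > 50000 nM. The one other result in the series is also a limit, so nothing here fixes a measured potency.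

The next compound is compound 3 `Cc1ccc(-c2ccsc2S(=O)(=O)NCCNC(=S)Nc2cc(C(F)(F)F)cc(C(F)(F)F)c2)c(Oc2ccc(O)c(O)c2)c1`. The change is methyl in place of hydrogen on an aromatic carbon, meta to a 3,4-dihydroxyphenoxy group and para to a large group.

Within the data shown here, the only measured step that bears on it is a step that the two limits leave unreadable from compound 1 to compound 2, which also concerns hydrogen and an alkyl group on an aromatic carbon. It rests on two results: the limit of > 20000 nM in this assay, at which 1 of the 2 values shown sits, and (the limit of > 50000 nM in this assay, at which 1 of the 2 values shown sits). That step has no readable size or direction, so no step beyond the scatter is expected in this assay.

The expected step is a number no higher from compound 2 to compound 3 (the limit leaves the size open). A result reported only as a limit is the likeliest outcome. The estimated value for compound 3 is 50000 nM, with an expected range of 20000 nM to 100000 nM.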

Compound 3, half-maximal inhibitory concentration: 8000 nM
Compound 3: the middle estimate sits 6.3-fold (0.80 log units) above what was measured, and the stated range ends above it.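

Methyl in place of hydrogen on the six-membered aromatic ring, meta to a 3,4-dihydroxyphenoxy group and para to a large group, produces in this assay an at least 6.2-fold lower number from compound 2 to compound 3 (0.79 log units; beyond the scatter), the first readable step in the series, since the earlier step between two limits cannot be read. At this position a single added carbon is enough to give a measured number: compound 3 gives 8000 nM. The step has only a minimum size, because compound 2 is fixed only by a limit: the limit of > 50000 nM in this assay, at which 1 of the 3 values shown sits.

Still open, going by these compounds, is whether this gain belongs to methyl itself or would also appear with an ethyl group, a methoxy group, a chlorine atom, an amine or a carboxylic acid at the same place on the ring. Also open is whether methyl gives the same step elsewhere on that ring, and whether the step seen in these HeLa cells would hold in any other readout, since the compounds shown rest on this single assay.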